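Exchanging benzyl for 4-bromophenyl on the thiazolidine carbon

This account rests on a few compounds, and the source may have more. Where it says the series, first, only, none or still open, it means among the compounds named here.

Compound 1 `CCCCCCCCCCCCCCCCCCNC(=O)[C@H]1CSC(Cc2ccccc2)N1` carries a benzyl group on a saturated ring carbon of its core. In a functional assay on PPC-1 cells (Homo sapiens) for antiproliferative activity, read by sulforhodamine B assay (on this read-out higher numbers stand for weaker inhibition and lower numbers for stronger inhibition), compound 1 gives 4000 nM. Compound 2 `CCCCCCCCCCCCCCCCCCNC(=O)[C@H]1CSC(c2cccc(O)c2)N1` gives 1200 nM, and compound 3 `CCCCCCCCCCCCCCCCCCNC(=O)[C@H]1CSC(c2ccc(F)cc2)N1` gives 2100 nM. Among these three numbers compound 1 stands highest: its nearest neighbour is compound 3, with a 1.9-fold lower number from compound 1 to compound 3 (0.28 log units; within the scatter), and its furthest is compound 2, with a 3.3-fold lower number from compound 1 to compound 2 (0.52 log units; beyond the scatter). Between compound 2 and compound 3 the step is a 1.8-fold higher number from compound 2 to compound 3 (0.24 log units; within the scatter).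

Compound 4 `CCCCCCCCCCCCCCCCCCNC(=O)[C@H]1CSC(c2ccc(Br)cc2)N1` differs from compound 1 as follows: 4-bromophenyl in place of benzyl on a saturated ring carbon

Among the compounds with values here, the steps that bear on this change are the two in which an aryl group replaces benzyl on the same saturated ring carbon, namely those from compound 1 to compound 2 and from compound 1 to compound 3, both of which gave lower numbers, one beyond the scatter and one within it. Compound 4 is therefore expected to follow the same direction, with an estimated step of a 2.2-fold lower number from compound 1 to compound 4 (0.35 log units; beyond the scatter). On this basis compound 4 is expected to give about 1800 nM in this assay, with a likely range from 700 nM to 4500 nM.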

Compound 4, half-maximal inhibitory concentration: 3700 nM
Beside the measured number, compound 4's estimate is 2.1-fold (0.31 log units) below it; the measured number falls inside the stated range.
By their numbers in this assay, from the lowest: compounds 2, 3, 4 and 1 (each within the scatter of the next, the first and the last beyond it).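

In this assay, within the data shown here, 4-bromophenyl on this saturated ring carbon leaves compound 4 within the scatter of the benzyl compound, with a 1.1-fold lower number from compound 1 to compound 4 (0.03 log units; within the scatter), so an aryl group at this place does not by itself separate a compound from compound 1, and compound 2 is the only one of the aryl compounds that stands apart from it. Bromo and fluoro on the aromatic carbon are not separated either, with a 1.8-fold higher number from compound 3 to compound 4 (0.25 log units; within the scatter), whereas 3-hydroxyphenyl stands apart from 4-bromophenyl, with a 3.1-fold higher number from compound 2 to compound 4 (0.49 log units; beyond the scatter). Nothing measured here gives a reason for these steps.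

Going by these compounds, whether 4-hydroxyphenyl or 3-aminophenyl on the same ring carbon would group with compound 2 or with compound 4 remains open. So does the outcome of a carboxylic acid on the aromatic ring, or of a shorter chain on the amide.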